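Replacing the methoxyphenyl amide with a bromophenyl amide

A few compounds are considered here, and "the series" means these few. Any claim that something is new, unique, unknown or untested is made for them only; others in the source may bear on it.

Of the compounds shown here, three sharing one core have been measured in an assay on LtK cells with ATP-sensitive inward rectifier potassium channel 11 (Homo sapiens) as the target; on this read-out lower numbers stand for an effect already at smaller amounts and higher numbers for an effect only at larger amounts of compound. Compound 1 `CC(=O)Nc1c(C(O)(C(F)(F)F)C(F)(F)F)ccc2ccccc12` gives 18 nM there, compound 2 `O=C(Nc1c(C(O)(C(F)(F)F)C(F)(F)F)ccc2ccccc12)C1CC1` gives 751 nM, and compound 3 `COc1cccc(C(=O)Nc2c(C(O)(C(F)(F)F)C(F)(F)F)ccc3ccccc23)c1` gives 185 nM. Compound 3 therefore stands second highest of the three numbers: the step of a 10-fold higher number from compound 1 to compound 3 (1.01 log units; beyond the scatter) is large, while the step of a 4.1-fold lower number from compound 2 to compound 3 (0.61 log units; beyond the scatter) is modest.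

Compound 4 `O=C(Nc1c(C(O)(C(F)(F)F)C(F)(F)F)ccc2ccccc12)c1ccc(Br)cc1` differs from compound 3 in one place: 4-bromophenyl in place of 3-methoxyphenyl on a carbonyl carbon. For the measured compounds named here, no measured step exchanges one aryl group for another on this carbonyl carbon; the two steps that end at compound 3 both replace a small alkyl group with the 3-methoxyphenyl group, so they show only that the aryl amide sits between the two alkyl amides in this assay and give no guide to the bromophenyl case.

Without a closer precedent, compound 4 is expected to stay near compound 3, with a step of a 1.6-fold higher number from compound 3 to compound 4 (0.21 log units; within the scatter) that may fall within the scatter. The estimate for compound 4 is 300 nM, with a range from 70 nM to 1300 nM.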

Compound 4, half-maximal effective concentration: 47 nM
For compound 4 the middle estimate is 6.4-fold (0.81 log units) above the measured one; the whole stated range lies above it.
By their numbers in this assay, from the lowest: compound 1; then compound 4; then compound 3; then compound 2.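

Which aryl group sits on this carbonyl carbon matters in this assay: with a 3.9-fold lower number from compound 3 to compound 4 (0.60 log units; beyond the scatter), exchanging 3-methoxyphenyl for 4-bromophenyl changes the result beyond the scatter, so an aryl amide cannot be treated as one fixed case. The aryl amides also span a wide range, since a 16-fold lower number from compound 2 to compound 4 (1.20 log units; beyond the scatter) places this one far from the cyclopropyl amide, while a 2.6-fold higher number from compound 1 to compound 4 (0.42 log units; beyond the scatter) still leaves it short of the small methyl amide. No measurement shown here accounts for these differences.

From the compounds shown here alone, the exchange alters both the substituent and its place on the ring, so it remains open whether the bromine or its position drives the step. A plain phenyl, a 3-bromophenyl or a 4-methoxyphenyl amide could separate these two changes, and an ethyl amide could show how the small alkyl amides behave between methyl and cyclopropyl.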